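This account rests on a few compounds, and the source may have more. Where it says the series, first, only, none or still open, it means among the compounds named here.

Compound 2 `COc1ccc(-c2cc3ccccc3nc2/C=C/C(=O)c2c(OC)cccc2OC)cc1` is a chalcone-like molecule in which a carbonyl carbon links a double-bonded chain to a 2,6-dimethoxyphenyl group. In a functional assay on NCI-H460 cells (Homo sapiens) for antiproliferative activity, read by XTT assay, with a stated time of 72 h (on this read-out higher numbers stand for weaker inhibition and lower numbers for stronger inhibition), compound 2 gives 6630 nM. Among the measured compounds shown here, its only measured companion is compound 1 `COc1ccc(-c2cc3ccccc3nc2/C=C/C(=O)c2ccc(OC)cc2OC)cc1`, which carries a 2,4-dimethoxyphenyl group at the same carbonyl carbon, and compound 1 gives 7040 nM. The move a 1.1-fold lower number from compound 1 to compound 2 (0.03 log units; within the scatter) is within the scatter, so the two numbers cannot be told apart.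

Compound 3 `COc1ccc(-c2cc3ccccc3nc2/C=C/C(=O)c2ccco2)cc1` replaces the dimethoxyphenyl entirely: furan-2-yl in place of 2,6-dimethoxyphenyl on a carbonyl carbon. For the measured compounds named here, the single measured step, shifting one methoxy group around the same ring, says nothing about swapping that ring for a smaller five-membered one bearing a ring oxygen. Going by the values given here, no measured step therefore bears directly on this change, and the expected direction is open. With that uncertainty, the estimated step is a 1.1-fold higher number from compound 2 to compound 3 (0.02 log units; within the scatter), meaning no movement beyond the scatter, though with a wide range. For compound 3 the expected value in this assay is 7000 nM, within a range from 2500 nM to 20000 nM.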

Compound 3, half-maximal inhibitory concentration: 6430 nM
Compound 3: middle estimate off by 1.1-fold (0.04 log units), on the high side; the measured number falls inside the stated range.
By their numbers in this assay, from the lowest: compounds 3, 2 and 1 (each within the scatter of the next).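

Among the compounds shown here, the earlier pair showed only that moving one methoxy group around the ring on this carbonyl carbon leaves the numbers indistinguishable. The new result tests a much larger replacement, exchanging the whole ring for furan-2-yl, and this too stays within the scatter in this assay (a 1.0-fold lower number from compound 2 to compound 3 (0.01 log units; within the scatter); a 1.1-fold lower number from compound 1 to compound 3 (0.04 log units; within the scatter)). The entering group has 5 heavy atoms, fewer than the group it replaces, one five-membered aromatic ring with 1 hetero atom rather than a six-membered ring of carbon only, and 1 hydrogen-bond acceptor rather than 2, yet among these three compounds none of these differences separates the numbers, and no supporting measurement is available to explain this result.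

The compounds shown leave open whether this carbonyl carbon would accept something other than an oxygen-containing aromatic ring, such as an unsubstituted phenyl ring, a pyridine ring, a ring carrying an amine or a carboxylic acid, or a longer alkyl chain. They also leave open whether any replacement here can move the number beyond the scatter, or whether changes elsewhere on the shared core would be needed to do so.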